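The source may report more compounds than this note shows. Statements on the series, on what has been measured and on what is new or still open speak of the compounds shown alone.

Compound 1 `O=c1c(Cc2coc3cccc(OCC4CCCCC4)c3c2=O)coc2ccccc12`: in a functional assay on NCI-H23 cells (Homo sapiens) for antiproliferative activity, read by XTT assay (on this read-out lower numbers stand for stronger inhibition and higher numbers for weaker inhibition), compound 1 gives 4130 nM.
Compound 2 `O=c1c(/C=C/c2coc3ccccc3c2=O)coc2ccccc12`: in this assay compound 2 reaches only the limit of the measurement, > 10000 nM.
Compound 3 `O=c1c(Cc2coc3cccc(OCC4CCCCC4)c3c2=O)coc2cc(Cl)ccc12`: in this assay compound 3 also reaches only the limit of the measurement, > 10000 nM.

Compound 1 is thus the only one of the three with a real number; the other two sit at the limit of > 10000 nM in this assay, at which 2 of the 3 values shown sit, so their true inhibition is weaker than the assay can resolve. Within the data shown here, the one step that can be sized runs from compound 1 to compound 3, where chloro replaces hydrogen on an aromatic carbon: an at least 2.4-fold higher number from compound 1 to compound 3 (0.38 log units; beyond the scatter).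

Compound 4 `CC(C)COc1cccc2occ(Cc3coc4ccccc4c3=O)c(=O)c12` differs from compound 1 in a different place: isopropyl in place of cyclohexyl on a saturated chain carbon bound to an oxygen on an aromatic ring. Among the measured compounds shown here, no measured pair shows this change, and the single sized step concerns another part of the molecule, so there is nothing that directly tells how the smaller isopropyl will behave. The change is therefore taken as likely to cost a little or to stay within the scatter, and compound 4 is expected to give about 6000 nM, with a range from 2000 nM to 18000 nM, which means an estimated 1.5-fold higher number from compound 1 to compound 4 (0.16 log units; within the scatter).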

Compound 4, half-maximal inhibitory concentration: > 10000 nM
Compound 4 ended at the assay's limit; the forecaster's own chance of this, stated with the estimate: 35%; middle value at least 1.6-fold (0.22 log units) away from the limit.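

The side group on the oxygen is not a free place to make changes: in this assay, replacing cyclohexyl with isopropyl on a saturated chain carbon bound to an oxygen on an aromatic ring gives an at least 2.4-fold higher number from compound 1 to compound 4 (0.38 log units; beyond the scatter). Among these compounds, until now, the only sized step lay elsewhere on the molecule, an at least 2.4-fold higher number from compound 1 to compound 3 (0.38 log units; beyond the scatter), so this is the first sign that the side group matters as well, and both single changes now point towards weaker inhibition. The full size of the new step stays unknown because compound 4 stands at a limit, not at a real number: the limit of > 10000 nM in this assay, at which 3 of the 4 values shown sit.

The change from cyclohexyl to isopropyl removes the ring and also goes from 6 heavy atoms to 3, so the compounds shown cannot tell which of the two matters, and a longer open chain of carbons in the same place could begin to separate them. They also leave open whether any group here, such as an amine or a carboxylic acid, would give a lower number than compound 1 does, since every single change shown so far has moved the number upward.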